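Removing a fluorine from a weakly cytotoxic triazole

The source may hold more compounds than are shown below. What is called first, only, known or untested is meant among the compounds shown, and "the series" means these compounds.

Measured so far:
- compound 1, `COc1cc(-c2nnc(SCc3ccccc3)n2/N=C/c2ccccc2)cc(OC)c1OC`: > 200000 nM
- compound 2, `COc1ccc(/C=N/n2c(SCc3ccc(F)cc3)nnc2-c2cc(OC)c(OC)c(OC)c2)c(OC)c1`: 126000 nM

Of the compounds shown here, two from this series have been tested in a functional assay on HT-29 cells (Homo sapiens) for cytotoxicity, read by MTT assay, with a stated time of 48 h; on this read-out lower numbers stand for stronger inhibition and higher numbers for weaker inhibition. For compound 1 the result is a limit of the assay rather than a number, at > 200000 nM. Among the compounds with values here, compound 2 is the only compound with a measured number, and in this assay compound 2 gives 126000 nM, a weak effect on the cells. Within the data shown here, no step between two measured compounds that differ in a single place is available, so the two results are best read side by side: one value stands at the limit (the limit of > 200000 nM in this assay, at which 1 of the 2 values shown sits), the other is a number somewhat below it.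

Compound 3, `COc1ccc(/C=N/n2c(SCc3ccccc3)nnc2-c2cc(OC)c(OC)c(OC)c2)c(OC)c1`, has not yet been measured. It differs from compound 2 in one place: hydrogen in place of fluoro on an aromatic carbon, which is hydrogen in place of fluoro on an aromatic carbon of the (4-fluorobenzyl)sulfanyl group, giving benzylsulfanyl. Such a small change is expected to move the value little, if at all, beyond the usual scatter. Compound 3 is therefore expected near compound 2, at about 150000 nM, within 60000 nM to 400000 nM, a step from compound 2 to compound 3 of a 1.2-fold higher number from compound 2 to compound 3 (0.08 log units; within the scatter).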

Compound 3, half-maximal inhibitory concentration: > 200000 nM
Compound 3: only a limit was reported; the forecaster's own chance of this, stated with the estimate: 40%; at least 1.3-fold (0.12 log units) between middle value and limit.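

In this assay compound 3 gives > 200000 nM, which is a limit of the assay and not a number. Within the data shown here, this is the first comparison that changes a single place, and going from 4-fluorobenzyl to benzyl gives an at least 1.5-fold higher number from compound 2 to compound 3 (0.20 log units; that floor lies within the scatter), so the fluoro group cannot yet be said to matter: the true gap may be larger, but the part that can be read does not clear the usual variation between repeat measurements. The step between compound 1 and compound 3 cannot be read, which leaves the change from phenyl to 2,4-dimethoxyphenyl without a size, and the series offers little room for comparison: the limit of > 200000 nM in this assay, at which 2 of the 3 values shown sit.

From the compounds shown here alone, whether a chlorine, a methoxy group or an amine on the same aromatic carbon would bring a value well clear of the limit stays open. Also open, going by these compounds, is whether a longer chain in place of the benzyl group would give a readable number, as compound 2 alone does so far, at 126000 nM.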